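The source may hold more compounds than are shown below. What is called first, only, known or untested is meant among the compounds shown, and "the series" means these compounds.

Compound 1 `COC(=O)C1=C(C)N=C(C)/C(=C(\O)OC)C1c1ccccc1Cl` is the most potent of the three measured compounds in a functional assay (muscle tissue) with Cavia porcellus as the target (on this read-out lower numbers stand for an effect already at smaller amounts and higher numbers for an effect only at larger amounts of compound), giving 2.19 nM. Compound 2 `C=Cc1ccccc1C1C(C(=O)OC)=C(C)N=C(C)/C1=C(\O)OC` gives 4.47 nM, while compound 3 `COC(=O)C1=C(C)N=C(C)/C(=C(\O)OC)C1c1ccc(I)cc1` gives 22900 nM. Compound 4 `COC(=O)C1=C(C)N=C(C)/C(=C(\O)OC)C1c1ccc(Cl)cc1Cl` differs from compound 1 by chloro in place of hydrogen on an aromatic carbon, placed meta to the chloro already present, so that 2-chlorophenyl becomes 2,4-dichlorophenyl. For the measured compounds named here, two measured steps bear on this: a 2.0-fold higher number from compound 1 to compound 2 (0.31 log units; beyond the scatter), a change of the existing ring group only, and a 10000-fold higher number from compound 1 to compound 3 (4.02 log units; beyond the scatter), which removes that chloro and adds a group at the position where compound 4 gains its chloro. Compound 4 keeps the chloro of compound 1, so a loss is expected but one well short of a 10000-fold higher number from compound 1 to compound 3 (4.02 log units; beyond the scatter); for compound 4 the expected step is a 9.1-fold higher number from compound 1 to compound 4 (0.96 log units; beyond the scatter). Compound 4 is estimated at 20 nM, between 3 nM and 200 nM.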

Compound 4, half-maximal effective concentration: 640 nM
The estimate for compound 4 lay 32-fold (1.51 log units) below the measured number; measured number outside the range, above it.
By their numbers in this assay, from the lowest: compound 1; then compound 2; then compound 4; then compound 3.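

With the chloro of compound 1 kept, adding a second chloro at this place, para to the large group, is enough on its own for a large loss (a 290-fold higher number from compound 1 to compound 4 (2.47 log units; beyond the scatter)). The earlier compounds shown here could not show this, as compound 3 also lacks that chloro. The 2,4-dichlorophenyl group still stays well short of 4-iodophenyl (a 36-fold lower number from compound 3 to compound 4 (1.55 log units; beyond the scatter)), yet lies far from 2-vinylphenyl (a 140-fold higher number from compound 2 to compound 4 (2.16 log units; beyond the scatter)), and nothing available here accounts for these steps. Open, on these data alone, is whether fluoro or methoxy at this place would bring a similar loss.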